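From Methyl to Benzyl in a Growth Inhibitor

The compounds below may be only part of what the source reports. "The series", "measured", "known", "first", "only" and "open" are said of these compounds alone.

Among the measured compounds shown here, only two compounds have been tested so far in a functional assay on MIA PaCa-2 cells (Homo sapiens) for inhibition, read by MTT assay, with a stated time of 72 h, tested at 30 uM (a lower number here means less inhibition of growth, a higher number more inhibition of growth at the concentration tested), and they set a wide gap. Compound 1 `C=CCc1cc(O)c(O)c(CN2CCC(C)CC2)c1` gives 91.5% and holds the higher of the two numbers. Compound 2 `C#CCOc1ccc(CC=C)cc1O` gives 27.4% and so falls short of compound 1 by a margin well beyond the usual scatter of repeated measurements. For the measured compounds named here, the two do not differ in just one place, so no measured step is available as a guide.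

Compound 3 `C=CCc1cc(O)c(O)c(CN2CCC(Cc3ccccc3)CC2)c1` keeps the core of compound 1 with one change phenyl in place of hydrogen on a saturated chain carbon bound to a saturated ring carbon that turns methyl into benzyl. With compound 1 at 91.5% there is little room for a rise, while a fall remains possible. The estimate in this assay is a number 2.5 percentage points lower from compound 1 to compound 3 (within the scatter) as a slight drop that stays within the scatter. Compound 3 is expected to give 89% with an estimated range from 68% to 99% in this test.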

Compound 3, percent growth inhibition at one concentration: 88.9%
Compound 3: middle estimate off by 0.1 percentage points, on the high side, and the stated range covers the measured number.
By their numbers in this assay, from the lowest: compound 2; then compounds 3 and 1 (each within the scatter of the next).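

In this assay, among the compounds shown here, the first single-place comparison in this set reads a number 2.6 percentage points lower from compound 1 to compound 3 (within the scatter), so this position, a saturated chain carbon bound to a saturated ring carbon, accepts phenyl in place of hydrogen with no change that can be told from the scatter. The change from methyl to benzyl adds 6 heavy atoms as one six-membered aromatic ring of carbon only, yet compound 1 at 91.5% and compound 3 at 88.9% cannot be separated in this test, though a single test concentration cannot show how the two would compare at lower concentrations. No separate measurement bears on why the result came out this way.

On these data alone, it remains open whether a carboxylic acid or an amine at this same place, or a longer chain ending in phenyl, would also leave the number where it stands. As far as these compounds go, it is equally open whether a pyridine ring in place of the phenyl would give a reading that falls beyond the scatter.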